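Replacing an anilide with a dimethoxybenzyl amide

A few compounds are considered here, and "the series" means these few. Any claim that something is new, unique, unknown or untested is made for them only; others in the source may bear on it.

Compound 1 `COc1ccc(C(=O)CSc2nnc(-c3cc(OC)c(OC)c(OC)c3)n2N)cc1` carries a 4-methoxyphenyl on its carbonyl carbon, and in a functional assay on PC-3 cells (Homo sapiens) for antiproliferative activity, read by MTT assay, with a stated time of 48 h (on this read-out higher numbers stand for weaker inhibition and lower numbers for stronger inhibition), compound 1 gives 97900 nM. Compound 2 `COc1cc(-c2nnc(SCC(=O)Nc3ccccc3C)n2N)cc(OC)c1OC` has (2-methylphenyl)amino in place of 4-methoxyphenyl on that carbonyl carbon. In this assay compound 2 reaches only a limit, > 100000 nM, so for compound 2 there is a limit and no number. The step of an at least 1.0-fold higher number from compound 1 to compound 2 (0.00 log units; that floor lies within the scatter) thus has only a floor, and that floor lies within the scatter. Compound 3 `COc1ccc(CNC(=O)CSc2nnc(-c3cc(OC)c(OC)c(OC)c3)n2N)cc1OC` is the next amide: 3,4-dimethoxybenzyl in place of 2-methylphenyl on an amide-type nitrogen. Among the measured compounds shown here, the only measured step bearing on it is that one, which sets nothing beyond the scatter, and since one of the two values sits at the limit of > 100000 nM in this assay, at which 1 of the 2 values shown sits, an estimate for compound 3 can only stay near that limit. Compound 3 is therefore expected to give 100000 nM, in a range from 50000 nM to 200000 nM, which means an expected step of a number no higher from compound 2 to compound 3 (the limit leaves the size open).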

Compound 3, half-maximal inhibitory concentration: > 100000 nM
Compound 3 was reported as a limit; the forecaster's own chance of this, stated with the estimate: 60%; the middle value lies on the limit itself.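

Compound 2 and compound 3 both stand at a limit and not at a number, so no step can be read between them, because the values give no size: the limit of > 100000 nM in this assay, at which 2 of the 3 values shown sit.

The compounds shown leave open whether 2-methylphenyl and 3,4-dimethoxybenzyl on the amide-type nitrogen differ at all in this assay.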